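Nucleobase swap on a furanone core: compound 1 to 3

The source may hold more compounds than are shown below. What is called first, only, known or untested is meant among the compounds shown, and "the series" means these compounds.

Compound 1 `NC1(CCn2cc(F)c(=O)[nH]c2=O)OC(=O)C(OCc2ccccc2)=C1OCc1ccccc1` and compound 2 `O=C1O/C(=C\Cn2ccc(NC(=O)c3ccccc3)nc2=O)C(OCc2ccccc2)=C1OCc1ccccc1` have both been run in a functional assay on SW-620 cells (Homo sapiens) for inhibition, read by MTT assay, with a stated time of 72 h; on this read-out lower numbers stand for stronger inhibition and higher numbers for weaker inhibition. In this assay compound 1 gives only a limit, > 100000 nM, and not a number. Compound 2 likewise gives only a limit in this assay, > 100000 nM. Among the measured compounds shown here, compound 1 thus stands at the limit of > 100000 nM in this assay, at which 2 of the 2 values shown sit, so no ranking within the measured pair is possible, and no step between measured compounds that differ in one place is available.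

Compound 3 `Nc1ccn(CCC2(N)OC(=O)C(OCc3ccccc3)=C2OCc2ccccc2)c(=O)n1` has not yet been measured. It differs from compound 1 by a group of 8 heavy atoms (4 carbon, 3 nitrogen, 1 oxygen; one six-membered aromatic ring with 2 hetero atoms) in place of a group of 9 heavy atoms (4 carbon, 2 nitrogen, 2 oxygen, 1 fluorine; one six-membered aromatic ring with 2 hetero atoms), on a saturated chain carbon, two bonds along the chain from a saturated ring carbon. With both known values sitting at the limit, the only expectation that the data support is that compound 3 remains in the same region, so a step from compound 1 of a step that the limit leaves unreadable from compound 1 to compound 3 in this assay is estimated, none beyond the scatter. Compound 3 is accordingly expected to give 150000 nM, with an estimated range from 30000 nM to 500000 nM, and most likely to be reported as a limit rather than as a number.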

Compound 3, half-maximal inhibitory concentration: > 100000 nM
Compound 3 was reported as a limit (the forecaster's own chance of this, stated with the estimate: 80%); the middle value does not contradict the limit.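

In this assay compound 3 gives > 100000 nM, a limit and not a number. No step can be read between compound 1 and compound 3, and the series stands at one value: the limit of > 100000 nM in this assay, at which 3 of the 3 values shown sit. The compounds shown leave open whether any change on the shared core gives a measurable value in this assay.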